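From ethoxy to methoxy at the assay's limit

The source may hold more compounds than are shown below. What is called first, only, known or untested is meant among the compounds shown, and "the series" means these compounds.

Compound 2 `CCOc1ncnc2c1ncn2C[C@@H]1C[C@H](CO)c2ccccc21` carries an ethoxy group on the shared core. In an ADME assay on L1210/0 cells (Mus musculus) for cytotoxicity, with a stated time of 48 h (a higher number here means a weaker inhibitor, a lower number a stronger inhibitor), compound 2 gives > 200000 nM as a limit of the assay and not a number. Compound 1 `COc1ncnc2c1ncn2C[C@@H]1C[C@H](O)c2ccccc21` gives > 200000 nM in the same test, and this too is a limit. The picture so far is therefore the limit of > 200000 nM in this assay, at which 2 of the 2 values shown sit, and nothing more.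

Compound 3 `COc1ncnc2c1ncn2C[C@@H]1C[C@H](CO)c2ccccc21` differs from compound 2 in one small way. The change is hydrogen in place of methyl on a saturated chain carbon bound to an oxygen on an aromatic ring and it puts hydrogen in place of methyl on a saturated chain carbon bound to an oxygen on an aromatic ring, which turns ethoxy to methoxy. Among the compounds with values here, no measured pair shows what this change does on its own.

Compound 2 is the nearest guide with its limit of > 200000 nM so no step beyond the scatter is expected in this assay for this change. The estimated step of a number no higher from compound 2 to compound 3 (the limit leaves the size open) is expected to stay within the scatter. Compound 3 is estimated at 200000 nM with an expected range from 100000 nM to 400000 nM in this test.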

Compound 3, half-maximal inhibitory concentration: > 200000 nM
Compound 3: no number, only a limit (the forecaster's own chance of this, stated with the estimate: 85%); the middle value lies on the limit itself.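

Compound 3 also ends at a limit of the assay and not at a number, so neither the step to it from compound 2 nor the step to it from compound 1 can be read. The compounds shown leave open whether ethoxy to methoxy, or hydroxy to hydroxymethyl, changes cytotoxicity at all. What stands is this: the limit of > 200000 nM in this assay, at which 3 of the 3 values shown sit.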